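The compounds below may be only part of what the source reports. "The series", "measured", "known", "first", "only" and "open" are said of these compounds alone.

Measured compounds:
compound 1, `CN1C[C@H](C(=O)Nc2ccc(C#N)cc2)[C@@H](c2ccc(/C=C/C(=O)Nc3ccccc3N)cc2)C1`, 1 mL/min/kg
compound 2, `CN1C[C@H](C(=O)Nc2ccc(Br)cc2)[C@@H](c2ccc(/C=C/C(=O)Nc3ccccc3N)cc2)C1`, 3 mL/min/kg
compound 3, `Cc1cc(NC(=O)[C@H]2CN(C)C[C@@H]2c2ccc(/C=C/C(=O)Nc3ccccc3N)cc2)ccc1Cl`, 15 mL/min/kg

In an in vitro ADME assay on microsomes from liver (Homo sapiens) for pharmacokinetics, read by LC-MS, with a stated time of 10 min, tested at 1 uM (on this read-out higher numbers stand for fast clearance and lower numbers for slow clearance), compound 2 stands second highest of the three numbers: the nearest is compound 1, with a 3.0-fold higher number from compound 1 to compound 2 (0.48 log units; beyond the scatter) between them, and the furthest is compound 3, with a 5.0-fold higher number from compound 2 to compound 3 (0.70 log units; beyond the scatter). Compound 4, `Cc1ccc(NC(=O)[C@H]2CN(C)C[C@@H]2c2ccc(/C=C/C(=O)Nc3ccccc3N)cc2)cn1`, has not yet been measured. It differs from compound 2 in one place: 6-methylpyridin-3-yl in place of 4-bromophenyl on an amide-type nitrogen.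

Both measured steps bear on this change, since each swaps the group on the same amide-type nitrogen. From cyano to bromo the number rose, as a 3.0-fold higher number from compound 1 to compound 2 (0.48 log units; beyond the scatter) shows, and from 4-bromophenyl to 4-chloro-3-methylphenyl it rose again, as a 5.0-fold higher number from compound 2 to compound 3 (0.70 log units; beyond the scatter) shows. Going by the values given here, neither step tells what a 6-methylpyridin-3-yl group does in its place; the data hold no compound bearing a ring nitrogen at this position. The expectation is therefore a step of no clear direction, probably within the scatter, and compound 4 is expected to sit close to compound 2, with the step of no change at the digits printed from compound 2 to compound 4 (within the scatter). Compound 4 is estimated at 3 mL/min/kg, with a range from 1 mL/min/kg to 9 mL/min/kg.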

Compound 4, clearance: 8 mL/min/kg
Compound 4: middle estimate off by 2.7-fold (0.43 log units), on the low side; the range from low to high includes it.
By their numbers in this assay, from the lowest: compound 1; then compound 2; then compounds 4 and 3 (each within the scatter of the next).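

In this assay, going by these compounds alone, the position on the amide-type nitrogen proves sensitive to a ring bearing a hetero atom, which no earlier compound could show: a 2.7-fold higher number from compound 2 to compound 4 (0.43 log units; beyond the scatter) is a step away from the 4-bromophenyl value, so 6-methylpyridin-3-yl is not a neutral replacement for 4-bromophenyl. The same group gives a 1.9-fold lower number from compound 3 to compound 4 (0.27 log units; within the scatter) against 4-chloro-3-methylphenyl, so those two compounds cannot be told apart here, while an 8.0-fold higher number from compound 1 to compound 4 (0.90 log units; beyond the scatter) shows that it stays well clear of the 4-cyanophenyl compound, which remains the lowest of the four. Nothing at hand says why the number moves with this change.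

From the compounds shown here alone, what stays open is whether the step belongs to the ring nitrogen or to the methyl group on that ring, a question that a plain pyridin-3-yl group on the same amide-type nitrogen would address. Also open, going by these compounds, is whether the low number of compound 1 would carry over to a 6-cyanopyridin-3-yl group, and how a 6-aminopyridin-3-yl group would read in this place.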